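Compound 4 against compound 3: a new aryl on the amide

The source may report more compounds than this note shows. Statements on the series, on what has been measured and on what is new or still open speak of the compounds shown alone.

In a functional assay on T47D cells (Homo sapiens) for inhibition, read by CCK-8 assay, with a stated time of 72 h, tested at 1 uM (on this read-out lower numbers stand for less inhibition of growth and higher numbers for more inhibition of growth at the one concentration tested), compound 1 `CN(C)C(=O)c1cc2cnc(Nc3ccc(NC(=O)C4(C(=O)Nc5ccccc5)CC4)cc3)nc2n1C1CCCC1` gives 52.8%, compound 2 `CN(C)C(=O)c1cc2cnc(Nc3ccc(NC(=O)C4(C(=O)Nc5cccc(O)c5)CC4)cc3)nc2n1C1CCCC1` gives 80.7%, and compound 3 `CN(C)C(=O)c1cc2cnc(Nc3ccc(NC(=O)C4(C(=O)Nc5ccc(Br)cc5)CC4)cc3)nc2n1C1CCCC1` gives 21.1%, the lowest of the three numbers. Compound 4 `CN(C)C(=O)c1cc2cnc(Nc3ccc(NC(=O)C4(C(=O)Nc5cccc(C(F)(F)F)c5)CC4)cc3)nc2n1C1CCCC1` differs from compound 3 by 3-(trifluoromethyl)phenyl in place of 4-bromophenyl on an amide-type nitrogen. Among the compounds with values here, two measured steps touch this amide nitrogen: a number 31.7 percentage points lower from compound 1 to compound 3 (beyond the scatter), and a number 59.6 percentage points lower from compound 2 to compound 3 (beyond the scatter), while a number 27.9 percentage points higher from compound 1 to compound 2 (beyond the scatter). Within the data shown here, no compound carrying a trifluoromethyl group has been measured, so the direction of the step is uncertain; since the hydrogen parent compound 1 sits well above compound 3, a moderate rise toward it is expected, a number 13.9 percentage points higher from compound 3 to compound 4 (beyond the scatter). Compound 4 is therefore estimated at 35% in this assay, with a range from 15% to 60%.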

Compound 4, percent growth inhibition at one concentration: 9.7%
Compound 4: middle estimate off by 25.3 percentage points, on the high side, and the stated range ends above it.
By their numbers in this assay, from the lowest: compound 4; then compound 3; then compound 1; then compound 2.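

In this assay, compound 4 gives the lowest number of the series, with a number 43.1 percentage points lower from compound 1 to compound 4 (beyond the scatter), and a number 71 percentage points lower from compound 2 to compound 4 (beyond the scatter). The 4-bromophenyl of compound 3 therefore did not mark the bottom at this amide-type nitrogen, as there is a number 11.4 percentage points lower from compound 3 to compound 4 (beyond the scatter). The 3-hydroxyphenyl and 3-(trifluoromethyl)phenyl groups fall on opposite sides of the unsubstituted phenyl of compound 1, so the substituent itself, not merely the presence of one, decides the direction of the step.

Nothing available accounts for this spread. On these data alone, whether an amino group or a carboxylic acid on this ring would follow the hydroxy of compound 2 or the trifluoromethyl of compound 4 stays open.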